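The compounds below may be only part of what the source reports. "The series", "measured", "known", "first", "only" and "open" are said of these compounds alone.

Of the compounds shown here, three built on a shared core have been tested in a functional assay on MOLT-4 cells (Homo sapiens) for antiproliferative activity, read by cell counting, with a stated time of 2 days; a higher number here means a weaker inhibitor, a lower number a stronger inhibitor. Compound 1 `COc1ccc(C(=O)c2sc(Nc3ccccc3)nc2N)cc1OC` gives 5500 nM. Compound 2 `COc1cc(C(=O)c2sc(Nc3ccc(F)cc3)nc2N)cc(OC)c1OC` gives 280 nM, the lower of the two exact numbers and clearly beyond the scatter from compound 1. Compound 3 `COc1ccc(C(=O)c2sc(Nc3ccc(Cl)cc3)nc2N)cc1` reads > 10000 nM, which is a limit of the assay and not a number.

Compound 4 `COc1cc(C(=O)c2sc(Nc3ccc(Cl)cc3)nc2N)cc(OC)c1OC` has not yet been measured. Its structure departs from that of compound 2 in a single place: chloro in place of fluoro on an aromatic carbon. This puts chloro in place of fluoro on an aromatic carbon, para to a large group. Going by the values given here, no pair of measured compounds shows this change on its own, so the expectation has to start from compound 2 at 280 nM. The expected step of a 1.4-fold higher number from compound 2 to compound 4 (0.15 log units; within the scatter) is small, probably within the scatter, and if anything slightly upward in the number. Compound 4 is estimated at 400 nM, with an expected range of 120 nM to 1500 nM.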

Compound 4, half-maximal inhibitory concentration: 110 nM
The estimate for compound 4 lay 3.6-fold (0.56 log units) above the measured number; the measured number lies below the stated range.
By their numbers in this assay, from the lowest: compound 4; then compound 2; then compound 1. At a limit, above all of these: compound 3.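

In this assay, going by these compounds alone, this pair gives the first direct reading of this position: putting chloro in place of fluoro gives a 2.5-fold lower number from compound 2 to compound 4 (0.41 log units; beyond the scatter), a modest step but one beyond the usual scatter. The position is therefore sensitive to which of these two halogens it carries, even though the change swaps one heavy atom for another and adds no ring, hydrogen-bond donor or acceptor, or net charge. Nothing measured here accounts for the step.

This step rests on a single pair, so it cannot be said whether chloro would also give a lower number on another version of the shared core. As far as these compounds go, how a bromo group, a methyl group or an amine at this place would compare also remains open.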